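The source may hold more compounds than are shown below. What is called first, only, known or untested is meant among the compounds shown, and "the series" means these compounds.

Working notes on the series. For the measured compounds named here, in a functional assay on RXF 393 cells (Homo sapiens) for inhibition, read by sulforhodamine B assay, with a stated time of 48 h (on this read-out lower numbers stand for stronger inhibition of growth and higher numbers for weaker inhibition of growth), compound 1 `COc1ccc(CNc2nc3cc(N)cc(N)c3nc2-c2ccccc2)cc1OC` gives 19100 nM, and compound 2 `Nc1cc(N)c2nc(-c3ccccc3)c(NCc3ccc(F)cc3)nc2c1` gives 12300 nM; the step of a 1.6-fold lower number from compound 1 to compound 2 (0.19 log units; within the scatter) leaves the two within the scatter of each other, so compound 2 stands level with compound 1 on the numbers so far. Compound 3 `Nc1cc(N)c2nc(-c3ccccc3)c(Oc3ccc(F)cc3)nc2c1` carries 4-fluorophenoxy in place of (4-fluorobenzyl)amino on an aromatic carbon. Going by the values given here, no measured step touches the link between the core and the fluorinated ring; the only step recorded, from compound 1 to compound 2, changes the fluorinated ring itself and cannot guide this one. For compound 3 a step of a 1.6-fold higher number from compound 2 to compound 3 (0.21 log units; within the scatter) is therefore expected only loosely, and its value in this assay is estimated at 20000 nM, within 6000 nM to 60000 nM.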

Compound 3, concentration for 50% growth inhibition: 19100 nM
Compound 3: the middle estimate sits 1.0-fold (0.02 log units) above what was measured; low and high end bracket the measured number.
By their numbers in this assay, from the lowest: compounds 2, 1 and 3 (each within the scatter of the next).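

In this assay, the step of a 1.6-fold higher number from compound 2 to compound 3 (0.19 log units; within the scatter) shows that this aromatic carbon next to the ring nitrogen takes 4-fluorophenoxy in place of (4-fluorobenzyl)amino with the values staying within the scatter. Neither the hydrogen-bond donor of (4-fluorobenzyl)amino nor its saturated chain carbon is thus required to hold the number at this level. Nothing measured explains this result. Going by these compounds, it remains open what a simple amine or a longer chain at this carbon, without the fluorinated ring, would give, and whether any group here moves the number beyond the scatter.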